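The compounds below may be only part of what the source reports. "The series", "measured", "known", "first", "only" and "open" are said of these compounds alone.

Among the three compounds measured in a functional assay on KM12 cells (Homo sapiens) for inhibition, read by sulforhodamine B assay, with a stated time of 48 h, tested at 10 uM (a higher number here means a weaker effect of the compound at the concentration tested, a lower number a stronger effect), compound 3 `COc1cc(Cl)cc(-c2nn(-c3cccc(NC(=O)c4ccc(Cl)c(Cl)c4)c3)cc2-c2ccncc2)c1` stands highest, giving 62.3%. Compound 2 `COc1cc(Cl)cc(-c2nn(-c3cccc(NC(=O)c4cc(C(F)(F)F)cc(C(F)(F)F)c4)c3)cc2-c2ccncc2)c1` gives 55.5%, which is within the scatter of compound 3, so the two cannot be ordered. Among the compounds with values here, compound 1 `COc1cc(Cl)cc(-c2nn(-c3cccc(NC(=O)Nc4ccc(Cl)c(C(F)(F)F)c4)c3)cc2-c2ccncc2)c1` gives 9.1%, and the step of a number 53.2 percentage points higher from compound 1 to compound 3 (beyond the scatter) is the only change measured in one place here; it is large and well beyond the scatter.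

Compound 4 `COc1cc(Cl)cc(-c2nn(-c3cccc(NC(=O)c4cccc(C(F)(F)F)c4)c3)cc2-c2ccncc2)c1` differs from compound 3 by 3-(trifluoromethyl)phenyl in place of 3,4-dichlorophenyl on a carbonyl carbon. Within the data shown here, no measured step exchanges one ring for another on the carbonyl carbon while keeping the amide: the step from compound 1 to compound 3 replaces the whole group on that carbon, so it bears only loosely on this change. Compounds 2 and 3, which both carry a ring on the carbonyl carbon, lie within the scatter of each other, so no step beyond the scatter is expected from compound 3 to compound 4 in this assay. Compound 4 is therefore estimated to give 57%, between 38% and 76%, a step of a number 5.3 percentage points lower from compound 3 to compound 4 (within the scatter) that is expected to stay within the scatter.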

Compound 4, a percentage reported as activity, at one concentration (the size of the read-out at that concentration, not a potency): 43.7%
Estimate against measurement, compound 4: 13.3 percentage points above; low and high end bracket the measured number.
By their numbers in this assay, from the lowest: compound 1; then compound 4; then compounds 2 and 3 (each within the scatter of the next).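

In this assay, the ring on the carbonyl carbon proves to matter even with the amide kept: 3-(trifluoromethyl)phenyl in place of 3,4-dichlorophenyl gives a number 18.6 percentage points lower from compound 3 to compound 4 (beyond the scatter), and hydrogen in place of trifluoromethyl on an aromatic carbon gives a number 11.8 percentage points lower from compound 2 to compound 4 (beyond the scatter), so the compound 4 ring reads a stronger effect than either ring before it. These ring changes remain smaller than the exchange of the whole group on that carbon, as a number 34.6 percentage points higher from compound 1 to compound 4 (beyond the scatter) still separates the two compounds. Nothing measured here explains these steps.

As far as these compounds go, whether the remaining gap to compound 1 comes from the amino nitrogen or from the ring chlorine stays open, as the two change together in that step. From the compounds shown here alone, how an unsubstituted phenyl, a methoxy group or an amine on this ring would read also remains open.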